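The source may report more compounds than this note shows. Statements on the series, on what has been measured and on what is new or still open speak of the compounds shown alone.

Measured so far in a functional assay on UACC-62 cells (Homo sapiens) for inhibition, read by sulforhodamine B assay, with a stated time of 48 h (a higher number here means a weaker inhibitor of growth, a lower number a stronger inhibitor of growth), for three compounds:

- compound 1 `S=C(N/N=C/c1cccs1)Nc1ccccc1` gives > 100000 nM as a limit
- compound 2 `S=C(N/N=C/c1cccs1)Nc1cccnc1` gives > 100000 nM as a limit
- compound 3 `S=C(N/N=C/c1cccs1)Nc1cccc2ccccc12` gives > 100000 nM as a limit

Compound 1 therefore has no exact number, and it stands at the limit of the test, in the same place as compound 2 and compound 3. The next compound to be tested is compound 4 `COc1ccc(NC(=S)N/N=C/c2cccs2)cc1`, which keeps the core of compound 1 and differs from it by methoxy in place of hydrogen on an aromatic carbon in one place: methoxy in place of hydrogen on an aromatic carbon, para to a large group. Going by the values given here, no measured pair of compounds differs in one place, so no direct step is available as a guide. The expectation rests instead on the limit of > 100000 nM in this assay, at which 3 of the 3 values shown sit, and on compound 1 with its limit of > 100000 nM as the starting point. In this assay the expected change is small, and the estimated a number no higher from compound 1 to compound 4 (the limit leaves the size open) lies within the scatter. Another result reported only as a limit is quite likely. For compound 4 the estimated value is 100000 nM within an expected range of 30000 nM to 300000 nM in this test.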

Compound 4, concentration for 50% growth inhibition: > 100000 nM
Compound 4 ended at the assay's limit (the forecaster's own chance of this, stated with the estimate: 65%); the middle value lies on the limit itself.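

Compound 1 and compound 4 both ended at the assay's limit, so the step between them, methoxy in place of hydrogen on an aromatic carbon, cannot be read: the limit of > 100000 nM in this assay, at which 4 of the 4 values shown sit.

The compounds shown leave open whether any change to the core of compound 1 gives a measurable growth inhibition in this assay.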